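A few compounds are considered here, and "the series" means these few. Any claim that something is new, unique, unknown or untested is made for them only; others in the source may bear on it.

Measured in a functional assay on A498 cells (Homo sapiens) for cytotoxicity; a higher number here means a weaker inhibitor of growth, a lower number a stronger inhibitor of growth:
- compound 1 `CSc1ccc(C2=C(c3ccc(F)c(F)c3)C(=O)N3CCCC3C2)cc1`: 100 nM
- compound 2 `CSc1ccc(C2=C(c3ccc(C)c(C)c3)C(=O)N3CCCC3C2)cc1`: 300 nM
- compound 3 `COc1ccc(C2=C(c3ccc(SC)cc3)CC3CCCN3C2=O)cc1OC`: 8000 nM

Compound 1 gives the lowest number of the three in this assay, so it is the strongest growth inhibitor measured so far. Compound 2 lies nearest to it, while compound 3 gives the highest number. Among the measured compounds shown here, no single-place step links compound 3 to compound 1, so it says little about the change considered here.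

The next compound, compound 4 `CSc1ccc(C2=C(c3ccc(C)cc3)C(=O)N3CCCC3C2)cc1`, has not yet been measured. It keeps the core of compound 1 and has 4-methylphenyl in place of 3,4-difluorophenyl on a double-bonded ring carbon.

For the measured compounds named here, one measured step bears on this change. At the same place, 3,4-dimethylphenyl in place of 3,4-difluorophenyl gives a 3.0-fold higher number from compound 1 to compound 2 (0.48 log units; beyond the scatter), a modest step beyond the scatter. Going by the values given here, no measured compound carries 4-methylphenyl, so this single step is only an indirect guide. A modest step of similar size, towards a higher number, therefore seems most likely, although a step within the scatter cannot be ruled out.

The expected step is a 2.5-fold higher number from compound 1 to compound 4 (0.40 log units; beyond the scatter). For compound 4 the estimated value is 250 nM, with an expected range of 90 nM to 700 nM.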

Compound 4, concentration for 50% growth inhibition: 4000 nM
For compound 4 the middle estimate is 16-fold (1.20 log units) below the measured one; measured number outside the range, above it.
By their numbers in this assay, from the lowest: compound 1; then compound 2; then compounds 4 and 3 (each within the scatter of the next).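

In this assay, among the compounds shown here, the group on the double-bonded ring carbon matters far more than the one earlier step at this place suggested. Where 3,4-dimethylphenyl in place of 3,4-difluorophenyl had given only a modest change (a 3.0-fold higher number from compound 1 to compound 2 (0.48 log units; beyond the scatter)), 4-methylphenyl in the same place gives a large one (a 40-fold higher number from compound 1 to compound 4 (1.60 log units; beyond the scatter)), and hydrogen in place of a single methyl on an aromatic carbon is also large (a 13-fold higher number from compound 2 to compound 4 (1.12 log units; beyond the scatter)), so among these three compounds the change in the number does not follow from the swap of fluorine for methyl alone, and the second substituent of compound 2 counts for much on its own. Nothing measured beyond these growth-inhibition numbers accounts for this large step, and the reason for it remains unknown.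

The compounds shown leave open whether a phenyl group with a single fluorine, an unsubstituted phenyl or a pyridine ring at this carbon would stay close to compound 1 or fall back towards compound 4. They also leave open whether the same steep dependence on this group would hold if the 4-(methylsulfanyl)phenyl group on the neighbouring ring atom were replaced by a methoxyphenyl or a chlorophenyl group.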